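Aryl Thioether in Place of a Short Alkyl Chain

This account rests on a few compounds, and the source may have more. Where it says the series, first, only, none or still open, it means among the compounds named here.

Compound 2 `CCCSc1nnc(-c2cc([N+](=O)[O-])cc([N+](=O)[O-])c2)n1Cc1ccccc1` was tested in an ADME assay on HepG2 cells (Homo sapiens) for cytotoxicity, with a stated time of 48 h; a lower number here means a stronger inhibitor, a higher number a weaker inhibitor. In this assay compound 2 gives > 30000 nM, which is a limit of the assay and not a number. Compound 1 `O=[N+]([O-])c1cc(CSc2nnc(-c3ccc(Cl)cc3)n2Cc2ccccc2)cc([N+](=O)[O-])c1` shows the same picture: in this assay compound 1 gives > 30000 nM, again a limit. So compound 2 stands together with compound 1 at the limit of > 30000 nM in this assay, at which 2 of the 2 values shown sit, and neither offers a real number to compare.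

Compound 3 `O=[N+]([O-])c1cc(-c2nnc(SCc3ccc(Cl)cc3)n2Cc2ccccc2)cc([N+](=O)[O-])c1` has not yet been measured in this assay. It differs from compound 2 by 4-chlorophenyl in place of ethyl on a saturated chain carbon bound to a sulfur. Within the data shown here, no measured step connects these two compounds, so the expectation rests only on what both measured values show. Because the two values shown sit at the limit of > 30000 nM in this assay, at which 2 of the 2 values shown sit, compound 3 is expected to come back at the same limit, with an expected step of a number no higher from compound 2 to compound 3 (the limit leaves the size open), that is, none beyond the scatter. Compound 3 is accordingly estimated at 30000 nM, with a range of 15000 nM to 60000 nM.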

Compound 3, half-maximal inhibitory concentration: > 30000 nM
Compound 3: no number, only a limit; the forecaster's own chance of this, stated with the estimate: 85%; the middle value lies on the limit itself.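

Compound 3, like compound 2, returns only a limit and not a number in this assay, so no step can be read between them: the limit of > 30000 nM in this assay, at which 3 of the 3 values shown sit. The compounds shown leave open whether 4-chlorophenyl in place of ethyl changes anything in this assay at all.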